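Aryl Amide in Place of Pentyl Amide: Expected Cytotoxicity

The source may report more compounds than this note shows. Statements on the series, on what has been measured and on what is new or still open speak of the compounds shown alone.

Compound 1 `C=CC1=C(C(=O)NCCCCC)C(c2ccc(OC)cc2)OC1` gives > 100000 nM in a functional assay on HeLa cells (Homo sapiens) for cytotoxicity, read by MTT assay, with a stated time of 24 h (on this read-out higher numbers stand for weaker inhibition and lower numbers for stronger inhibition), which is a limit of the assay and not a number.
Compound 2 `C=CC1=C(C(=O)NCc2ccc(C)cc2)C(c2ccc(F)cc2)OC1` gives > 100000 nM, also a limit.

Compound 1 thus stands where every value shown sits, as the limit of > 100000 nM in this assay, at which 2 of the 2 values shown sit, records. Compound 3 `C=CC1=C(C(=O)Nc2ccc(C)cc2)C(c2ccc(OC)cc2)OC1` differs from compound 1 by 4-methylphenyl in place of pentyl on an amide-type nitrogen. Among the compounds with values here, no step between measured compounds is available, so the data give no direction for this change; the step that the limit leaves unreadable from compound 1 to compound 3 is expected to stay within the scatter, with a limit the most likely outcome again. Compound 3 is expected to give 150000 nM, with a range from 40000 nM to 500000 nM.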

Compound 3, half-maximal inhibitory concentration: > 100000 nM
Compound 3: a limit, no number; the forecaster's own chance of this, stated with the estimate: 75%; the middle value does not contradict the limit.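

Within the data shown here, compound 1 and compound 3 both sit at a limit of the assay and not at a number, so no step between them can be read. The compounds shown leave open whether 4-methylphenyl in place of pentyl changes anything in this assay.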